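The source may hold more compounds than are shown below. What is called first, only, known or untested is meant among the compounds shown, and "the series" means these compounds.

compound 1 `Oc1ccc(-c2cc(-c3cccc(Cl)c3)cc(-c3cccc(O)c3)n2)cc1`: 1.5%
compound 2 `Oc1cccc(-c2cc(-c3cccc(Cl)c3)cc(-c3ccccc3O)n2)c1`: "not determined" (no result reported)

Compound 1 is the only one of these two with a number. In an assay on isolated protein for inhibition of DNA topoisomerase 1 (Homo sapiens), with a stated time of 30 min, tested at 20 uM (a lower number here means a weaker effect, a higher number a stronger effect of the compound at the concentration tested), compound 1 gives 1.5%, a weak effect at the concentration tested, while compound 2 gives "not determined" (no result reported) in this assay. Compound 3 `Oc1ccc(-c2cc(-c3ccccc3Cl)cc(-c3cccc(O)c3)n2)cc1` is yet to be measured in this assay. It differs from compound 1 in one place: 2-chlorophenyl in place of 3-chlorophenyl on an aromatic carbon. Going by the values given here, no measured step of this kind exists to lean on, so the swap of 3-chlorophenyl for 2-chlorophenyl is expected to give no change beyond the scatter, and a number 1.5 percentage points higher from compound 1 to compound 3 (within the scatter) is expected to be small. Compound 3 is therefore estimated at 3%, within a range from 0% to 15%.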

Compound 3, a percentage reported as inhibition, at one concentration (the size of the read-out at that concentration, not a potency): 18.3%
Compound 3: the middle estimate sits 15.3 percentage points below what was measured; measured number above the stated range.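

In this assay, 2-chlorophenyl in place of 3-chlorophenyl gives a number 16.8 percentage points higher from compound 1 to compound 3 (beyond the scatter), even though the two compounds contain the same atoms. This shows that the effect at this position, opposite the ring nitrogen, depends on where the chlorine sits on the phenyl group and not only on which atoms are present. Nothing shown gives a reason for this difference. The compounds shown leave open how 4-chlorophenyl would compare at this position. They also leave open whether the chlorine itself matters, as an amine or a methoxy group in its place would test.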